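This account rests on a few compounds, and the source may have more. Where it says the series, first, only, none or still open, it means among the compounds named here.

Compound 1 `Cc1cc(=O)oc2cc(OCc3cn(-c4ccccc4F)nn3)ccc12`: in an ADME assay on Huh-7 cells (Homo sapiens) for cytotoxicity, read by MTT assay, with a stated time of 72 h (a higher number here means that more compound is tolerated, a lower number that less compound is tolerated), compound 1 gives > 100 ug/mL, which is a limit of the assay rather than a number.
Compound 2 `COc1cc(-n2cc(COc3ccc4c(C)cc(=O)oc4c3)nn2)cc(OC)c1OC`: in this assay compound 2 gives > 100 ug/mL, likewise a limit of the assay.

Compound 1 therefore stands at the limit of > 100 ug/mL in this assay, at which 2 of the 2 values shown sit, so no exact figure is known for it. Compound 2 sits at that same limit, and the two compounds cannot be told apart on these numbers. Compound 3 `Cc1cc(=O)oc2cc(OCc3cn(Cc4ccccc4)nn3)ccc12` has not yet been measured in this assay. It differs from compound 1 in a single place: benzyl in place of 2-fluorophenyl on an aromatic nitrogen. Among the compounds with values here, no step between two measured compounds is available to show what such a change does to cytotoxicity here. Because every value shown sits at the limit of > 100 ug/mL in this assay, at which 2 of the 2 values shown sit, the step of a number no higher from compound 1 to compound 3 (the limit leaves the size open) is expected to be none beyond the scatter. Compound 3 is expected to give 100 ug/mL, in the range 50 ug/mL to 200 ug/mL, and most likely to return only a limit as well.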

Compound 3, half-maximal cytotoxic concentration: > 100 ug/mL
Compound 3: a limit, no number; the forecaster's own chance of this, stated with the estimate: 85%; the middle value sits exactly at the limit.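

Compound 1 and compound 3 both return only a limit of the assay, so benzyl in place of 2-fluorophenyl gives no step that can be read: the limit of > 100 ug/mL in this assay, at which 3 of the 3 values shown sit.

The compounds shown leave open where the true half-maximal cytotoxic concentration of each lies in this assay, and whether benzyl and 2-fluorophenyl differ there at all.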